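A Smaller Group on the Carbonyl Carbon

The compounds below may be only part of what the source reports. "The series", "measured", "known", "first", "only" and "open" are said of these compounds alone.

- compound 1 `Nc1nc2c(s1)CCC[C@H]2C(=O)Nc1ccc(C[C@@H]2CC[C@H]([C@H](O)c3ccccc3)N2)cc1`: 63 mL/min/kg
- compound 2 `Nc1nc2c(s1)CC[C@H]2C(=O)Nc1ccc(C[C@@H]2CC[C@H]([C@H](O)c3cccnc3)N2)cc1`: 57 mL/min/kg

In an ADME assay (liver) for metabolic stability, with Liver microsome (Rattus norvegicus) as the target, using microsomes (on this read-out higher numbers stand for fast clearance and lower numbers for slow clearance), compound 1 stands within the usual scatter of compound 2, so neither value sets it apart. Compound 3 `O=C(Nc1ccc(C[C@@H]2CC[C@H]([C@H](O)c3ccccc3)N2)cc1)[C@@H]1CCc2scnc21` has not yet been measured. It differs from compound 1 on a carbonyl carbon: a group of 8 heavy atoms (6 carbon, 1 nitrogen, 1 sulfur; one five-membered non-aromatic ring of carbon only, one five-membered aromatic ring with 2 hetero atoms) in place of a group of 10 heavy atoms (7 carbon, 2 nitrogen, 1 sulfur; one five-membered aromatic ring with 2 hetero atoms, one six-membered non-aromatic ring of carbon only), on a carbonyl carbon. The two measured compounds differ in more than one place, so no single change has been measured to guide the expectation. No step beyond the scatter is expected, and the estimated step of a 1.1-fold lower number from compound 1 to compound 3 (0.02 log units; within the scatter) reflects that. Compound 3 is expected at 60 mL/min/kg, with an estimated range of 35 mL/min/kg to 100 mL/min/kg.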

Compound 3, clearance: 68 mL/min/kg
The estimate for compound 3 lay 1.1-fold (0.05 log units) below the measured number; measured number inside the range.
By their numbers in this assay, from the lowest: compounds 2, 1 and 3 (each within the scatter of the next).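

In this assay, the exchange on this carbonyl carbon gives the first single-place comparison, a 1.1-fold higher number from compound 1 to compound 3 (0.03 log units; within the scatter) and so the two groups are not told apart on this read-out. The group that enters has 0 hydrogen-bond donors and 2 hydrogen-bond acceptors against 1 and 3 in the group that leaves, and this difference in counts leaves the clearance within the scatter. No measurement at hand offers an explanation for this result. Going by these compounds, whether a much smaller group on this carbonyl carbon, such as methyl, or a plain phenyl ring would give a number beyond the scatter remains open.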